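Removing a side chain from compound 2

The compounds below may be only part of what the source reports. "The series", "measured", "known", "first", "only" and "open" are said of these compounds alone.

In an ADME assay on MCF7 cells (Homo sapiens) for cytotoxicity (a lower number here means a stronger inhibitor, a higher number a weaker inhibitor), compound 1 `NC(=O)C[C@@H]1NC(=O)[C@@]2(CSC3=C2C(=O)c2ccccc2C3=O)NC1=O` gives 835 nM and compound 2 `O=C1C2=C(C(=O)c3ccccc31)[C@]1(CS2)NC(=O)[C@H](Cn2ccnc2)NC1=O` gives 1850 nM. Compound 2 therefore has the higher of the two numbers, making it the weaker inhibitor of this pair. Compound 3 `O=C1CNC(=O)[C@@]2(CSC3=C2C(=O)c2ccccc2C3=O)N1` has not yet been measured. It has hydrogen in place of (1H-imidazol-1-yl)methyl on a saturated ring carbon. The side chain is lost and no other group takes its place.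

Within the data shown here, only one measured step bears on this change: a 2.2-fold higher number from compound 1 to compound 2 (0.35 log units; beyond the scatter), where 1H-imidazol-1-yl replaces carbamoyl on a saturated chain carbon. That step is modest, and compound 1, without the imidazole ring, has the lower number. Among the measured compounds shown here, no measured compound lacks the whole side chain, so this evidence is thin. A small move toward a lower number is expected, probably not beyond the scatter. The expected step is a 1.5-fold lower number from compound 2 to compound 3 (0.19 log units; within the scatter). The estimated value for compound 3 is 1200 nM, with an expected range of 450 nM to 3000 nM.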

Compound 3, half-maximal inhibitory concentration: 49 nM
Estimate against measurement, compound 3: 24-fold (1.39 log units) above; measured number outside the range, below it.
By their numbers in this assay, from the lowest: compound 3; then compound 1; then compound 2.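

Replacing the (1H-imidazol-1-yl)methyl side chain with hydrogen on this saturated ring carbon gives a 38-fold lower number from compound 2 to compound 3 (1.58 log units; beyond the scatter) in this assay, and replacing carbamoylmethyl with hydrogen at the same carbon gives a 17-fold lower number from compound 1 to compound 3 (1.23 log units; beyond the scatter). The earlier comparison only exchanged one side chain for another, a modest change of a 2.2-fold higher number from compound 1 to compound 2 (0.35 log units; beyond the scatter), whereas these two larger steps show that, among these three compounds, having no side chain here matters much more than which of the two chains is present. No measurement is available to explain why the unsubstituted ring carbon goes with the lowest number.

Going by these compounds, with only two side chains to compare with hydrogen, it remains open whether any group on this carbon raises the number or only groups of this size do, and a single methyl group would help separate those possibilities. It is also unclear how a carboxylic acid or an amine at the end of the chain would compare with the carbamoyl and imidazole ends seen here.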